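The source may report more compounds than this note shows. Statements on the series, on what has been measured and on what is new or still open speak of the compounds shown alone.

Working notes on the series. The shared core is seen in compound 1 `O=C(CCCCCCc1ccc(Cl)cc1)N1CCCC1`, which in an assay on HEK293 cells for inhibition of N-acylethanolamine-hydrolyzing acid amidase (Rattus norvegicus), read by LC-MS, with a stated time of 30 min (a lower number here means a stronger inhibitor, a higher number a weaker inhibitor), gives 34500 nM. Compound 3 `CCCc1ccc(CCCCCCC(=O)N2CCCC2)cc1` gives > 100000 nM, a limit of this assay rather than a number. Within the data shown here, the only measured step, an at least 2.8-fold higher number from compound 1 to compound 3 (0.46 log units; beyond the scatter), therefore ends at a limit. Compound 2 `Cc1ccccc1-c1ccc(CCC(=O)N2CCCC2)cc1` likewise gives > 100000 nM, again a limit and not a number. On the numbers shown, compound 2 stands with compound 3 at the limit of > 100000 nM in this assay, at which 2 of the 3 values shown sit; compound 1 alone carries a measured value.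

The unmeasured compound 4 `O=C(CCc1ccc(-c2ccsc2)cc1)N1CCCC1` differs from compound 2 in one place (thiophen-3-yl in place of 2-methylphenyl on an aromatic carbon). Among the measured compounds shown here, no measured step concerns a change of this kind: the single step available, propyl in place of chloro on an aromatic carbon, belongs to the chain-linked compounds, was at least modest, and ran toward the limit. It gives no ground to expect a move toward a lower number for compound 4, and nothing in the shown values does. Compound 4 is thus expected to stay weak, at 90000 nM, with a range from 30000 nM to 300000 nM. The estimated step of an at least 1.1-fold lower number from compound 2 to compound 4 (0.04 log units; that floor lies within the scatter) is accordingly none beyond the scatter, with a sizeable chance that this assay again reports only a limit.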

Compound 4, half-maximal inhibitory concentration: 2500 nM
Compound 4: middle estimate off by 36-fold (1.56 log units), on the high side; measured number outside the range, below it.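

In this assay, thiophen-3-yl in place of 2-methylphenyl gives an at least 40-fold lower number from compound 2 to compound 4 (1.60 log units; beyond the scatter), so the group at this place, on an aromatic carbon para to a group of 9 heavy atoms, can decide between a measurable number and a limit. The only earlier step, an at least 2.8-fold higher number from compound 1 to compound 3 (0.46 log units; beyond the scatter), ran the opposite way and belongs to the chain-linked compounds, so the series had not yet shown a single change in one place that gives a lower number. The full size of the new step stays unknown because compound 2 carries a limit of the assay and not a number: the limit of > 100000 nM in this assay, at which 2 of the 4 values shown sit.

The compounds shown do not separate the ring size, the sulfur and the loss of the methyl group, as thiophen-3-yl differs from 2-methylphenyl in all three at once. Going by these compounds, whether unsubstituted phenyl, thiophen-2-yl or furan-3-yl at this place keeps a number like that of compound 4, and what an amine or a carboxylic acid on the same ring would do, remains open.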